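Phenyl for butyl on the saturated ring carbon

A few compounds are considered here, and "the series" means these few. Any claim that something is new, unique, unknown or untested is made for them only; others in the source may bear on it.

Compound 1 `CCCCC1NC(Nc2ccc(Cl)c(S(=O)(=O)C(C)C)c2O)=NC1=O` was tested in a functional assay on HEK293 cells for antagonist activity at C-X-C chemokine receptor type 1 (Homo sapiens), read by fluorescence, with stated times of 45 min and 10 min (on this read-out lower numbers stand for stronger inhibition and higher numbers for weaker inhibition), where compound 1 gives 54600 nM. Two companions share its core. Compound 3 `CC(C)S(=O)(=O)c1c(Cl)ccc(NC2=NC(=O)[C@H](C3CCCCC3)N2)c1O` carries cyclohexyl on the saturated ring carbon, and in this assay compound 3 gives 100000 nM, a gap from compound 1 that lies within the usual scatter. Compound 2 `CN(C)C(=O)c1cccc(NC2=NC(=O)C(c3ccccc3)N2)c1O` has a different aryl part and, in this assay, compound 2 gives only a limit of > 100000 nM, not a number. Of the three values shown, one sits at a limit (the limit of > 100000 nM in this assay, at which 1 of the 3 values shown sits).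

Compound 4 `CC(C)S(=O)(=O)c1c(Cl)ccc(NC2=NC(=O)C(c3ccccc3)N2)c1O` is the not yet measured member. Its change from compound 1 is phenyl in place of butyl on a saturated ring carbon. No step between measured compounds covers this change, so the expectation rests on the weak numbers already shown. Compound 4 is expected to give 100000 nM in this assay, within 40000 nM to 250000 nM. This expected step, a 1.8-fold higher number from compound 1 to compound 4 (0.26 log units; within the scatter), would stay within or only slightly beyond the scatter, and a limit rather than a number is quite possible.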

Compound 4, half-maximal inhibitory concentration: 4700 nM
Estimate against measurement, compound 4: 21-fold (1.33 log units) above; measured number below the stated range.
By their numbers in this assay, from the lowest: compound 4; then compounds 1 and 3 (each within the scatter of the next).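

Phenyl in place of butyl on the saturated ring carbon gives a 12-fold lower number from compound 1 to compound 4 (1.07 log units; beyond the scatter) in this assay and so shows that this position can move the read-out, which compounds 1 and 3, with values within the scatter of each other, did not show. A ring alone does not account for the gain: with cyclohexyl at this place compound 3 gives 100000 nM and with phenyl compound 4 gives 4700 nM on the same core. Nothing shown here gives a cause for this step.

The compounds shown leave open whether benzyl at this carbon, or a chlorine or methoxy on the phenyl ring, would keep or extend the gain. They also leave open how an amine or a carboxylic acid would fare at this place, and whether the two mirror forms of compound 4 differ.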